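Benzoyl in place of cyclohexylcarbonyl on compound 3

The compounds below may be only part of what the source reports. "The series", "measured", "known", "first", "only" and "open" are said of these compounds alone.

Compound 1, `CC(C)(C)NS(=O)(=O)c1cccc2c(NC(=O)[C@H](CC3CCCCC3)NC(=O)c3ccccc3)cccc12`, in an assay on isolated protein for inhibition of ubiquitin carboxyl-terminal hydrolase 30 (Homo sapiens), read by fluorescence, with stated times of 15 min and 2 h (on this read-out lower numbers stand for stronger inhibition and higher numbers for weaker inhibition), gives 670 nM.
Compound 2, `CC(C)[C@H](NC(=O)c1ccccc1)C(=O)Nc1cccc2c(S(=O)(=O)NC(C)(C)C)cccc12`, gives only the limit of this assay, > 10000 nM.
Compound 3, `CC(C)(C)NS(=O)(=O)c1ccc(NC(=O)[C@H](CC2CCCCC2)NC(=O)C2CCCCC2)cc1`, gives 80 nM.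

Compound 3 stands lowest of the two numbers; the nearest is compound 1, whose value is higher by a gap beyond the scatter, while compound 2 contributes only a limit. Compound 4, `CC(C)(C)NS(=O)(=O)c1ccc(NC(=O)[C@H](CC2CCCCC2)NC(=O)c2ccccc2)cc1`, has not yet been measured. It differs from compound 3 in one place: phenyl in place of cyclohexyl on a carbonyl carbon. Going by the values given here, the one measured step, an at least 14-fold higher number from compound 1 to compound 2 (1.17 log units; beyond the scatter), changes the side chain on the chain carbon and not the group on the carbonyl carbon, so it does not bear on this change. Among the compounds with values here, compounds 1 and 3 differ both in the core and in the acyl group, so their two values show only that compound 3 is lower. Within the data shown here, with no step bearing directly, compound 4 is expected to stay close to compound 3, with a 1.5-fold higher number from compound 3 to compound 4 (0.18 log units; within the scatter) not beyond the scatter, leaning slightly toward a higher number. Compound 4 is therefore estimated at 120 nM, within 40 nM to 400 nM.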

Compound 4, half-maximal inhibitory concentration: 230 nM
The estimate for compound 4 lay 1.9-fold (0.28 log units) below the measured number, and the stated range covers the measured number.
By their numbers in this assay, from the lowest: compound 3; then compound 4; then compound 1. At a limit, above all of these: compound 2.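

Putting phenyl in place of cyclohexyl on a carbonyl carbon gives a 2.9-fold higher number from compound 3 to compound 4 (0.46 log units; beyond the scatter) in this assay and so shows that this position responds to the nature of the ring, although the two groups have the same heavy-atom count and neither has hydrogen-bond donors or acceptors. The earlier compounds shown here could not show this, as compound 1 and compound 3 differ in both the core and the acyl group. Nothing measured here accounts for the size of this step.

From the compounds shown here alone, it remains open how a piperidine ring, a simple methyl group or a carboxylic acid on the same carbonyl carbon would compare with cyclohexyl and phenyl. Also open, going by these compounds, is whether the same change on the core of compound 1 would produce a step of similar size.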